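The compounds below may be only part of what the source reports. "The series", "measured", "known", "first", "only" and "open" are said of these compounds alone.

Measured in a physicochemical assay for solubility, in phosphate buffer, measured as kinetic solubility, with a stated time of 1 h, at pH 7.4; a higher number here means a more soluble compound, a lower number a less soluble compound:
- compound 1 `CS(=O)(=O)Cc1cc(C2=CCOCC2)nc(-c2cccc(O)c2)n1`: 27 ug/mL
- compound 2 `CCNC(=O)Nc1ccc(-c2nccc([C@]34CCOC[C@H]3C4)n2)cc1`: 125 ug/mL

Compound 1 holds the lower of these two numbers, and the gap up to compound 2 lies beyond the usual scatter of repeat measurements. The two compounds differ in more than one place, so this gap cannot be pinned on any single group.

The next compound, compound 3 `Oc1cccc(-c2nccc(C3=CCOCC3)n2)c1`, comes from compound 1 through one change: hydrogen in place of (methylsulfonyl)methyl on an aromatic carbon. Put simply, hydrogen stands in place of (methylsulfonyl)methyl on an aromatic carbon. Within the data shown here, no measured pair shows this change on its own, so the data offer no direct guide to its effect. The expectation in this assay is a slight rise at most, with no step beyond the scatter. The estimated step is a 1.3-fold higher number from compound 1 to compound 3 (0.11 log units; within the scatter). For compound 3 the expected value is 35 ug/mL, with an estimated range from 10 ug/mL to 110 ug/mL.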

Compound 3, solubility: 113 ug/mL
Estimate against measurement, compound 3: 3.2-fold (0.51 log units) below, outside the stated range (above it).
By their numbers in this assay, from the lowest: compound 1; then compounds 3 and 2 (each within the scatter of the next).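

Among these compounds, with hydrogen in place of (methylsulfonyl)methyl on this aromatic carbon, the only single-change pair so far gives, in this assay, a 4.2-fold higher number from compound 1 to compound 3 (0.62 log units; beyond the scatter) and the rest of the structure stays the same. This shows that what sits at this position, on the six-membered aromatic ring with 2 nitrogen, can move the number by more than the scatter, and that here the compound without the group holds the higher number. No measurement shown speaks to what lies behind this step.

A single pair cannot tell whether the whole group or only part of it matters, or whether the same swap would give a similar step on another core. Methyl, an amine or a carboxylic acid on this carbon would test how the number follows the group placed there.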